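Acetyl to Cyano Swap on a Shared Core

A few compounds are considered here, and "the series" means these few. Any claim that something is new, unique, unknown or untested is made for them only; others in the source may bear on it.

Of the compounds shown here, two with the same core have been tested in a functional assay on SK-OV-3 cells (Homo sapiens) for inhibition, read by sulforhodamine B assay, with a stated time of 48 h; a higher number here means a weaker inhibitor of growth, a lower number a stronger inhibitor of growth. Compound 1 `COc1ccc2[nH]c(-c3ccccc3)c(C=C(C#N)C#N)c2c1` gives 4800 nM, and compound 2 `CC(=O)/C(=C\c1c(-c2ccccc2)[nH]c2ccccc12)S(=O)(=O)c1ccccc1` gives 2900 nM. These two numbers lie within the usual scatter of each other, so neither compound can be called the stronger inhibitor of growth. Compound 3 `N#C/C(=C\c1c(-c2ccccc2)[nH]c2ccccc12)S(=O)(=O)c1ccccc1` has not yet been measured. It differs from compound 2 by cyano in place of acetyl on a double-bonded chain carbon bound to a double-bonded chain carbon and a sulfonyl sulfur. For the measured compounds named here, no measured pair shows this exact change, so its effect in this assay is unknown, and no step beyond the scatter is expected in either direction. Compound 3 is expected to give about 2500 nM, with a likely range from 900 nM to 7000 nM. The expected step is a 1.2-fold lower number from compound 2 to compound 3 (0.06 log units; within the scatter).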

Compound 3, concentration for 50% growth inhibition: 6800 nM
For compound 3 the middle estimate is 2.7-fold (0.43 log units) below the measured one; low and high end bracket the measured number.
By their numbers in this assay, from the lowest: compounds 2, 1 and 3 (each within the scatter of the next, the first and the last beyond it).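

On a double-bonded chain carbon bound to a double-bonded chain carbon and a sulfonyl sulfur, cyano in place of acetyl gives a 2.3-fold higher number from compound 2 to compound 3 (0.37 log units; beyond the scatter) in this assay and so shows that growth inhibition responds to the group at this position. The step is modest, but of these two groups, acetyl gives the stronger inhibitor. No measurement at hand explains the step. As far as these compounds go, whether an amide, a carboxylic acid or a longer ketone chain here would match or improve on acetyl stays open, as does whether this swap would act alike on another core.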